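A methyl on the hydrazine nitrogen of compound 1

The source may hold more compounds than are shown below. What is called first, only, known or untested is meant among the compounds shown, and "the series" means these compounds.

Compound 1, `CC(C)N(N)c1nnc(-c2ccccc2Cl)s1`: in a functional assay on the whole organism with Mus musculus as the target, with a stated time of 1 h (on this read-out lower numbers stand for an effect already at smaller amounts and higher numbers for an effect only at larger amounts of compound), compound 1 gives > 100 mg/kg, which is a limit of the assay.
Compound 2, `NN(c1ccccc1)c1nnc(-c2ccccc2Cl)s1`: in this assay compound 2 gives > 100 mg/kg, again a limit.
Compound 3, `CC(C)N(N)c1nnc(-c2ccccc2-c2ccccc2)s1`: in this assay compound 3 gives > 100 mg/kg, again a limit.

Compound 1 therefore has no number of its own, only (the limit of > 100 mg/kg in this assay, at which 3 of the 3 values shown sit). Both changes made to it so far stay at that limit: the step that the two limits leave unreadable from compound 1 to compound 2 and the step that the two limits leave unreadable from compound 1 to compound 3 cannot be read in either direction, and they say nothing about the size of a change elsewhere in the molecule.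

Compound 4, `CNN(c1nnc(-c2ccccc2Cl)s1)C(C)C`, differs from compound 1 only by methyl in place of hydrogen on an amine nitrogen. For the measured compounds named here, no measured step bears on this change, and nothing in the three values suggests that any part of the shared core carries a readable effect. The expectation for compound 4 is thus that it most likely also comes back as a limit, with the step that the limit leaves unreadable from compound 1 to compound 4 expected to be within the scatter. Compound 4 is estimated at 150 mg/kg, in a range from 60 mg/kg to 400 mg/kg.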

Compound 4, dose for half-maximal effect: > 100 mg/kg
Compound 4: no number, only a limit; the forecaster's own chance of this, stated with the estimate: 75%; the middle value does not contradict the limit.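

Compound 1 and compound 4 each give only a limit in this assay, so the step from hydrogen to methyl on the amine nitrogen cannot be read in either direction. The compounds shown leave open which change, if any, would give a readable dose: the limit of > 100 mg/kg in this assay, at which 4 of the 4 values shown sit.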